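Hydrogen in place of methyl on compound 2

This account rests on a few compounds, and the source may have more. Where it says the series, first, only, none or still open, it means among the compounds named here.

Values in an ADME assay on J774 cells (Mus musculus) for antiproliferative activity, with a stated time of 72 h (on this read-out higher numbers stand for an effect only at larger amounts of compound and lower numbers for an effect already at smaller amounts), are as follows:
Compound 1 `COC(=O)c1c[nH]c2cc(OC)c(Cl)cc2c1=O` gives 37000 nM as an exact number
Compound 2 `CCc1c(C)[nH]c2cc(OCCOc3ccccc3)c(C)cc2c1=O` gives > 30000 nM as a limit
Compound 3 `CCc1c(C)[nH]c2cc(OCCCN3CCN(c4ccccc4)CC3)c(Cl)cc2c1=O` gives > 23000 nM as a limit

Compound 2 stands at the limit of > 30000 nM in this assay, at which 1 of the 3 values shown sits, and so has no exact value. For the measured compounds named here, compound 3 is the other compound with only a limit, which leaves compound 1 as the one exact number.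

Going by the values given here, compound 4 `CCc1c(C)[nH]c2cc(OCCOc3ccccc3)ccc2c1=O` has not yet been measured in this assay and carries hydrogen in place of methyl on an aromatic carbon, ortho to a large group hydrogen in place of methyl on an aromatic carbon as its only difference from compound 2. Among the compounds with values here, no measured pair shows this change. With compound 1 at 37000 nM as the only exact reference, a similarly high value is expected. The estimated a number no higher from compound 2 to compound 4 (the limit leaves the size open) is expected to stay within the usual scatter, with neither direction favoured. For compound 4 the estimate is 30000 nM with an expected range from 12000 nM to 70000 nM and a real chance of another limit.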

Compound 4, half-maximal effective concentration: 4000 nM
Beside the measured number, compound 4's estimate is 7.5-fold (0.88 log units) above it; measured number outside the range, below it.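

In this assay, hydrogen in place of methyl on an aromatic carbon, ortho to a large group, brings an at least 7.5-fold lower number from compound 2 to compound 4 (0.87 log units; beyond the scatter). The earlier compounds shown here differ from one another in more than one place and could not isolate any single position, whereas here the loss of one heavy atom alone turns a limit into an exact value. The step has only a lower bound and its full size stays open, because compound 2 carries a limit and no exact number: the limit of > 30000 nM in this assay, at which 1 of the 4 values shown sits.

The compounds shown leave open what a fluorine atom or a nitrile would give on this aromatic carbon. They also leave open whether the same change would give a similar step with a different side chain, such as the phenylpiperazine chain of compound 3.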